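The compounds below may be only part of what the source reports. "The series", "measured", "known", "first", "only" and "open" are said of these compounds alone.

Measured compounds:
Compound 1 `O=C(O)c1cn(Cc2ccc(-n3cccn3)cc2)c2cccc(F)c2c1=O`: 88.4%
Compound 2 `O=C(O)c1cn(Cc2ccc(-n3ccc4ncccc43)cc2)c2cccc(F)c2c1=O`: 93%

In an ADME assay on a cell-free system (plasma, Rattus norvegicus) for protein binding, compound 1, at 88.4%, cannot be told apart from compound 2, as the two values lie within the scatter of each other. Compound 3 `O=C(O)c1cn(Cc2ccc(-n3cccn3)cc2)c2c(F)ccc(F)c2c1=O` keeps all of compound 1 and adds one change: fluoro in place of hydrogen on an aromatic carbon, para to a fluoro group (fluoro in place of hydrogen on an aromatic carbon). For the measured compounds named here, only one measured step is available, a 1.7-fold lower unbound fraction from compound 1 to compound 2 (0.22 log units; within the scatter). Going by the values given here, it exchanged a different group in another place, so it bears on this change only loosely, and no measured step touches the carbon that changes here. Even that much larger exchange stayed within the scatter. An estimated step of a 1.2-fold lower unbound fraction from compound 1 to compound 3 (0.06 log units; within the scatter) is therefore expected, none beyond the scatter. For compound 3 the expected value is 90%, with an estimated range from 85% to 94%.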

Compound 3, plasma protein binding: 95.7%
For compound 3 the middle estimate is 2.3-fold (0.37 log units) (unbound fraction) above the measured one; the whole stated range lies below it.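

In this assay, adding a single fluoro group to the core of compound 1 gives a 2.7-fold lower unbound fraction from compound 1 to compound 3 (0.43 log units; beyond the scatter), so a change of one heavy atom on this aromatic carbon, para to a fluoro group, moves the read-out beyond the scatter. The earlier step, which exchanged a larger group in another place, stayed within the scatter, so across these compounds the number of atoms changed does not track the size of the step. Nothing available explains why this position responds as it does.

From the compounds shown here alone, whether the step belongs to fluoro specifically, or would also appear with chloro or a methoxy group on this carbon, stays open. So does whether fluoro here would give a similar step alongside the larger group that compound 2 carries.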